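Carboxy in Place of Fluoro: an Expected Read-out

This account rests on a few compounds, and the source may have more. Where it says the series, first, only, none or still open, it means among the compounds named here.

Compound 1 `Oc1cccc2cc(-c3ccc(F)cc3)ccc12` was tested in an assay for binding affinity to 17-beta-hydroxysteroid dehydrogenase type 1 (Homo sapiens), with a stated time of 20 min, tested at 1 uM; a higher number here means more inhibition at the concentration tested (going by the name of the read-out), a lower number less inhibition. In this assay compound 1 gives < 10%, which is a limit of the assay rather than a number. Compound 2 `N#Cc1ccc(-c2ccc3c(O)cccc3c2)cc1` carries a cyano in place of the fluoro, and in this assay compound 2 gives 16%. Among the compounds with values here, the step of a number at least 6 percentage points higher from compound 1 to compound 2 (that floor lies within the scatter) is the only measured change, and its floor lies within the scatter. Compound 3 `O=C(O)c1ccc(-c2ccc3c(O)cccc3c2)cc1` differs from compound 1 by carboxy in place of fluoro on an aromatic carbon. Within the data shown here, no measured step carries a carboxy, so no movement beyond the scatter is expected. Compound 3 is therefore estimated at 14%, between 4% and 30%. The expected step is a number at least 4 percentage points higher from compound 1 to compound 3 (that floor lies within the scatter).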

Compound 3, a percentage reported as inhibition, at one concentration (the size of the read-out at that concentration, not a potency): < 10%
Compound 3 was reported as a limit (the forecaster's own chance of this, stated with the estimate: 35%); middle value at least 4 percentage points away from the limit.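

Compound 3 gives < 10% in this assay, which is a limit and not a number. Against cyano, the change to carboxy gives a number at least 6 percentage points lower from compound 2 to compound 3 (that floor lies within the scatter), so this position does not yet separate the two groups beyond the scatter. The step from fluoro to carboxy cannot be read, both of its ends being limits, and the read-out at this position remains crowded at its floor: the limit of < 10% in this assay, at which 2 of the 3 values shown sit.

From the compounds shown here alone, whether an amine or a methoxy at this place would rise clear of that limit stays open. So does whether any group here can move the read-out beyond the scatter.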